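A few compounds are considered here, and "the series" means these few. Any claim that something is new, unique, unknown or untested is made for them only; others in the source may bear on it.

Compound 1, with the structure `CCCCCCCC/C=C\CCCCCCCC(=O)N[C@H]1[C@@H](OCCCCCCCC)O[C@H](CO)[C@@H](O)[C@@H]1O`, is one of three glycolipids measured in a functional assay on U-373MG ATCC cells (Homo sapiens), read by thymidine incorporation; on this read-out lower numbers stand for stronger inhibition and higher numbers for weaker inhibition. In this assay compound 1 gives 13.3 uM, the second highest of the three numbers. Compound 3, with the structure `CCCCCCCC/C=C\CCCCCCCC(=O)N[C@H]1[C@@H](OCCCCCCCC)O[C@H](COCC(CO)(CO)CO)[C@@H](O)[C@@H]1O`, gives 20.6 uM, and the change a 1.5-fold higher number from compound 1 to compound 3 (0.19 log units; within the scatter) is within the scatter. Compound 2, with the structure `CCCCCCCCCCCCCCCCO[C@H]1O[C@H](COCC(CO)(CO)COS(=O)(=O)O)[C@@H](O)[C@H](O)[C@H]1NC(=O)CCCC`, gives 3.2 uM, a lower number than that of compound 1; compound 2 differs from compound 1 in several places at once, so no single step can be read from the pair.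

Compound 4, with the structure `CCCCCCCC/C=C\CCCCCCCC(=O)N[C@H]1[C@@H](OCCCCCCCC)O[C@H](CO)[C@@H](O)[C@@H]1OS(=O)(=O)O`, differs from compound 1 by sulfo in place of hydrogen on an oxygen on a saturated carbon. Among the measured compounds shown here, no measured step bears directly on this change. For the measured compounds named here, the only single-place step in the set, a 1.5-fold higher number from compound 1 to compound 3 (0.19 log units; within the scatter), also alters an oxygen on a saturated carbon and stays within the scatter, while compound 2, which carries a sulfo group among its other differences, shows a lower number than compound 1. On this evidence a small lowering of the number is expected for compound 4, and the expected step is a 1.7-fold lower number from compound 1 to compound 4 (0.22 log units; within the scatter). Compound 4 is therefore estimated to give 8 uM in this assay, with a range from 3 uM to 25 uM.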

Compound 4, concentration for 50% inhibition: 15.6 uM
Estimate against measurement, compound 4: 2.0-fold (0.29 log units) below; low and high end bracket the measured number.
By their numbers in this assay, from the lowest: compound 2; then compounds 1, 4 and 3 (each within the scatter of the next).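

In this assay, sulfo in place of hydrogen on this oxygen on a saturated carbon, the change of hydroxy to sulfooxy, gives a 1.2-fold higher number from compound 1 to compound 4 (0.07 log units; within the scatter). Among the compounds shown here, this is the first direct reading of a sulfo group in the set. Compound 2 carries its sulfo group together with several other differences from compound 1, whereas compound 4 differs from compound 1 in this one place only; at this place, adding the sulfo group leaves the number within the scatter, so the lower number of compound 2 cannot be attributed to a sulfo group at this position. Nothing available explains why this exchange leaves the read-out within the scatter.

The compounds shown leave open whether a carboxylic acid, an amine or a methyl ether on this same oxygen would also stay within the scatter of compound 1, and whether a sulfo group on another oxygen of the shared core would do the same. For the compounds shown here, they also leave open which of the several differences carried by compound 2 goes with its number, since no single-place step connects it to the other compounds.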